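The source may report more compounds than this note shows. Statements on the series, on what has been measured and on what is new or still open speak of the compounds shown alone.

Among the three measured compounds, compound 3 `CCOc1ccc(O)c(C(=O)/C=C/c2ccc(O)c(O)c2)c1` stands lowest in an assay on RBL-1 cells for inhibition of Polyunsaturated fatty acid 5-lipoxygenase (Rattus norvegicus) (a lower number here means a stronger inhibitor, a higher number a weaker inhibitor), at 5.3 nM. Compound 2 `O=C(/C=C/c1ccc(O)c(O)c1)c1cc(O)ccc1O` gives 64 nM, and compound 1 `COc1cc(/C=C/C(=O)c2ccccc2O)ccc1O` gives 17000 nM. Going by the values given here, the one single-place step in this set, a 12-fold lower number from compound 2 to compound 3 (1.08 log units; beyond the scatter), is large. Compound 4 `CCCCOc1ccc(O)c(C(=O)/C=C/c2ccc(O)c(O)c2)c1` differs from compound 3 by ethyl in place of hydrogen on a saturated chain carbon, two bonds along the chain from an oxygen on an aromatic ring. That step from compound 2 to compound 3 bears on this change only loosely, since here the chain is lengthened further out rather than begun; a step of that size is not expected again. The expected step is a 1.3-fold lower number from compound 3 to compound 4 (0.12 log units; within the scatter), small and perhaps within the scatter. Compound 4 is therefore estimated to give 4 nM, with a range from 1.5 nM to 12 nM.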

Compound 4, half-maximal inhibitory concentration: 1000 nM
Compound 4: the middle estimate sits 250-fold (2.40 log units) below what was measured; the measured number lies above the stated range.
By their numbers in this assay, from the lowest: compound 3; then compound 2; then compound 4; then compound 1.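

In this assay, chain length on this oxygen does more than change the size of the effect; it reverses its direction. Lengthening ethoxy to butoxy gives a 190-fold higher number from compound 3 to compound 4 (2.28 log units; beyond the scatter), and butyl in place of hydrogen on the oxygen gives a 16-fold higher number from compound 2 to compound 4 (1.19 log units; beyond the scatter), so the butyl ether falls on the weaker side of the free phenol, whereas the ethyl ether fell on the stronger side. Nothing available explains this reversal.

The compounds shown leave open whether a propyl chain would stay close to ethyl or fall towards butyl. They also leave open how a longer chain, or an amine at the chain end, would read.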